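The source may report more compounds than this note shows. Statements on the series, on what has been measured and on what is new or still open speak of the compounds shown alone.

Working notes on the series. Compound 1 `COc1ccccc1-c1noc(C(C)C)c1COc1ccc(/C=C/c2cccc(C(=O)O)c2)c(Cl)c1` gives 250 nM in an assay on isolated protein for displacement of a labelled ligand from Bile acid receptor (Homo sapiens), read by scintillation proximity assay and radioligand binding; a lower number here means a stronger inhibitor, a higher number a weaker inhibitor. Going by the values given here, compound 2 `CC(C)c1onc(-c2ccc(S(C)(=O)=O)cc2Cl)c1COc1ccc(/C=C/c2cccc(C(=O)O)c2)c(Cl)c1` gives 170 nM in this assay; the one measured step, a 1.5-fold lower number from compound 1 to compound 2 (0.17 log units; within the scatter), exchanges the aryl group attached to the shared core and stays inside the scatter. Compound 3 `Cc1cc(OCc2c(-c3c(Cl)ccc(=O)n3C)noc2C(C)C)ccc1-c1ccc2c(C(=O)O)cn(C)c2c1` gives 235 nM in this assay and sits with the other two, within the usual scatter of compound 1 and of compound 2. Compound 4 `Cc1cc(OCc2c(-c3c(Cl)cn(C)c(=O)c3Cl)noc2C(C)C)ccc1-c1ccc2c(C(=O)O)cn(C)c2c1` differs from compound 3 by a group of 10 heavy atoms (6 carbon, 1 nitrogen, 1 oxygen, 2 chlorine; one six-membered aromatic ring with 1 hetero atom) in place of a group of 9 heavy atoms (6 carbon, 1 nitrogen, 1 oxygen, 1 chlorine; one six-membered aromatic ring with 1 hetero atom), on an aromatic carbon. Among the compounds with values here, this is the same kind of exchange as the one from compound 1 to compound 2, which was within the scatter, so no step beyond the scatter is expected, no change at the digits printed from compound 3 to compound 4 (within the scatter). Compound 4 is therefore estimated at 235 nM in this assay, range 100 nM to 550 nM.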

Compound 4, half-maximal inhibitory concentration: 2750 nM
Compound 4: middle estimate off by 12-fold (1.07 log units), on the low side; the whole stated range lies below it.
By their numbers in this assay, from the lowest: compounds 2, 3 and 1 (each within the scatter of the next); then compound 4.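

This position is not indifferent to the aryl group it carries: in this assay, a 12-fold higher number from compound 3 to compound 4 (1.07 log units; beyond the scatter), although the exchange between compound 1 and compound 2 stayed within the scatter. The groups match in hydrogen-bond donors, acceptors and net charge, so those counts do not separate compound 3 from compound 4, whose group holds 2 chlorine against 1. Nothing available accounts for the step. Still open, as far as these compounds go, is whether the second chlorine or its changed ring arrangement carries the loss, and whether fluorine or a nitrile there would do the same. From the compounds shown here alone, the size of this step on the core of compound 1 also remains open.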